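The compounds below may be only part of what the source reports. "The series", "measured", "known", "first", "only" and "open" are said of these compounds alone.

Measured so far:
- compound 1, `Cc1n[nH]c(C(=O)O)c1Cc1ccc2ccccc2n1`: 18%
- compound 2, `Cc1n[nH]c(C(=O)O)c1Cc1cccc(-c2cccc(F)c2)c1`: 50%
- compound 3, `Cc1n[nH]c(C(=O)O)c1Cc1ccc(C(F)(F)F)cc1`: 12%

In an assay on isolated protein for inhibition of 2-Hydroxyacid oxidase 2 (Homo sapiens), tested at 10 uM (a higher number here means a stronger effect of the compound at the concentration tested, a lower number a weaker effect), compound 2 gives the highest of the three numbers; compound 1 and compound 3 both sit lower, each beyond the usual scatter. Among the compounds with values here, no step between two measured compounds that differ in a single place is known, so the effect of a small change has no anchor yet.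

Compound 4, `Cc1n[nH]c(C(=O)O)c1Cc1cccc(-c2ccccc2F)c1`, is not yet measured. It differs from compound 2 as follows: 2-fluorophenyl in place of 3-fluorophenyl on an aromatic carbon. Within the data shown here, with no comparable step in this assay to lean on, the expectation is a modest change, in either direction, that may not exceed the scatter. For compound 4 the estimate is 40%, in the range 20% to 60%, which means an expected step of a number 10 percentage points lower from compound 2 to compound 4 (within the scatter).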

Compound 4, a percentage reported as inhibition, at one concentration (the size of the read-out at that concentration, not a potency): 22%
The estimate for compound 4 lay 18 percentage points above the measured number, within the range that was stated.
By their numbers in this assay, from the lowest: compounds 3, 1 and 4 (each within the scatter of the next); then compound 2.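

Working with the same atoms, 2-fluorophenyl in place of 3-fluorophenyl, on an aromatic carbon meta to a large group, gives in this assay a number 28 percentage points lower from compound 2 to compound 4 (beyond the scatter). Within the data shown here, this is the first single-place step, and it shows that the read-out is sensitive to where the fluorine stands on this outer ring. No available data give a reason for the step.

Open, on these data alone, is how a plain phenyl or a 4-fluorophenyl would compare with compound 2 at this place. Also open, as far as these compounds go, is whether an amine on this ring would be tolerated.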